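Removing the Thiazole Ester from the Weakest Analogue

The compounds below may be only part of what the source reports. "The series", "measured", "known", "first", "only" and "open" are said of these compounds alone.

Compound 1 `CCOC(=O)c1sc(NC(=O)Cn2cc(-c3cccs3)nn2)nc1C` gives 20 nM in a functional assay on BMDM cells (Mus musculus, strain C57BL/6) for inhibition, with a stated time of 2 days; a higher number here means a weaker inhibitor, a lower number a stronger inhibitor.
Compound 2 `CCOC(=O)c1sc(NC(=O)Cn2cc(-c3ccc(Cl)cc3)nn2)nc1C` gives 180 nM in this assay.
Compound 3 `CCOC(=O)c1sc(NC(=O)Cn2cc(-c3ccc(OC)cc3)nn2)nc1C` gives 2330 nM in this assay.

Compound 3 carries the highest number of the three measured compounds. Against compound 1 the gap is a 120-fold higher number from compound 1 to compound 3 (2.07 log units; beyond the scatter), and against compound 2 it is a 13-fold higher number from compound 2 to compound 3 (1.11 log units; beyond the scatter); both steps lie beyond the scatter, so compound 3 is the weakest inhibitor of the set.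

Compound 4 `COc1ccc(-c2cn(CC(=O)Nc3nc(C)cs3)nn2)cc1` differs from compound 3 in one place: hydrogen in place of ethoxycarbonyl on an aromatic carbon. Among the measured compounds shown here, every measured step so far exchanges one aryl group for another at the far end of the molecule, and the shared core with its ethoxycarbonyl group is untouched in all three compounds. For the measured compounds named here, no measured step therefore bears on this change, and its size and direction cannot be read from the data. Given only that compound 3 is already the weakest, compound 4 is estimated at 6000 nM, between 1000 nM and 40000 nM, which means an expected step of a 2.6-fold higher number from compound 3 to compound 4 (0.41 log units; beyond the scatter), with a real chance that only a limit is reported.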

Compound 4, half-maximal inhibitory concentration: 3890 nM
The estimate for compound 4 lay 1.5-fold (0.19 log units) above the measured number; measured number inside the range.
By their numbers in this assay, from the lowest: compound 1; then compound 2; then compounds 3 and 4 (each within the scatter of the next).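

Among the compounds shown here, compound 4 gives the first reading at the aromatic carbon next to the ring sulfur: in this assay, hydrogen in place of ethoxycarbonyl gives a 1.7-fold higher number from compound 3 to compound 4 (0.22 log units; within the scatter) and so no change that can be told from scatter. Where the earlier steps exchanged only the aryl group at the far end of the molecule, this pair shows that, with 4-methoxyphenyl in place, the number stays within the scatter when the whole ethoxycarbonyl group leaves. No measurement at hand accounts for this outcome.

As far as these compounds go, whether the same exchange is as quiet with thiophen-2-yl or 4-chlorophenyl at the far end remains open, as this step stands for 4-methoxyphenyl alone. Also open, from the compounds shown here alone, is how a carboxylic acid or a primary amide on this aromatic carbon would compare with ethoxycarbonyl and hydrogen.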